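This account rests on a few compounds, and the source may have more. Where it says the series, first, only, none or still open, it means among the compounds named here.

Measured so far in this series:

Compound 1 `O=C(O)CCCCCCC(=O)Nc1ccc(C2=C(c3ccc(O)cc3)C3CC(S(=O)(=O)Oc4ccc(F)cc4)C2O3)cc1`: 24800 nM
Compound 2 `O=C(O)CCCCCCC(=O)Nc1ccc(C2=C(c3ccc(O)cc3)C3CC(S(=O)(=O)Oc4cccc5ccccc45)C2O3)cc1`: 4700 nM
Compound 3 `O=C(CCCCCCC(=O)Nc1ccc(C2=C(c3ccc(O)cc3)C3CC(S(=O)(=O)Oc4cccc5ccccc45)C2O3)cc1)NO`: 13400 nM

In a functional assay on MCF7 cells (Homo sapiens) for inhibition, read by MTT assay, with a stated time of 72 h (on this read-out lower numbers stand for stronger inhibition and higher numbers for weaker inhibition), compound 2 stands lowest of the three numbers; its steps to compound 3 and to compound 1 both lie beyond the scatter, a 2.9-fold higher number from compound 2 to compound 3 (0.46 log units; beyond the scatter) and, read the other way, a 5.3-fold lower number from compound 1 to compound 2 (0.72 log units; beyond the scatter).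

Compound 4 `Cc1ccc(OS(=O)(=O)C2CC3OC2C(c2ccc(NC(=O)CCCCCCC(=O)O)cc2)=C3c2ccc(O)cc2)cc1` is the next member to be measured. It differs from compound 2 in one place: 4-methylphenyl in place of naphthalen-1-yl on an oxygen. The group that leaves carries two six-membered aromatic rings; the group that enters carries one, on the same oxygen bound to the sulfonyl sulfur.

Among the compounds with values here, the one measured step that bears on this place is the move from compound 1 to compound 2, a 5.3-fold lower number from compound 1 to compound 2 (0.72 log units; beyond the scatter), where a single six-membered aromatic ring on that oxygen was replaced by naphthalen-1-yl. Compound 4 returns to a single ring, so the expectation is a step back in the direction of compound 1, probably somewhat smaller, since the single ring is not the same one.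

For compound 4 the expected step is a 3.2-fold higher number from compound 2 to compound 4 (0.50 log units; beyond the scatter), and the estimated value is 15000 nM with a range of 6000 nM to 40000 nM.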

Compound 4, half-maximal inhibitory concentration: 60500 nM
For compound 4 the middle estimate is 4.0-fold (0.61 log units) below the measured one; the whole stated range lies below it.
By their numbers in this assay, from the lowest: compound 2; then compounds 3 and 1 (each within the scatter of the next); then compound 4.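

On the oxygen bound to the sulfonyl sulfur, the single-ring groups are not interchangeable: in this assay, methyl in place of fluoro on an aromatic carbon gives a 2.4-fold higher number from compound 1 to compound 4 (0.39 log units; beyond the scatter) and so moves the number beyond the scatter with the ring count unchanged. The change from naphthalen-1-yl to 4-methylphenyl gives a 13-fold higher number from compound 2 to compound 4 (1.11 log units; beyond the scatter) while the other single-ring comparison gives a 5.3-fold lower number from compound 1 to compound 2 (0.72 log units; beyond the scatter) so the size of the difference between naphthalen-1-yl and a single ring depends on which single ring is compared. No measurement at hand gives a reason for these differences.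

Still open is where an unsubstituted phenyl or a naphthalen-2-yl on this oxygen would fall among these numbers. Also open, as far as these compounds go, is whether hydroxyamino in place of hydroxy on the carbonyl carbon would shift the number in the same direction with 4-methylphenyl on this oxygen.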